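A chlorine swap on compound 2

The source may report more compounds than this note shows. Statements on the series, on what has been measured and on what is new or still open speak of the compounds shown alone.

In a functional assay on A549 cells (Homo sapiens) for antiproliferative activity, read by MTT assay, with a stated time of 72 h (on this read-out lower numbers stand for stronger inhibition and higher numbers for weaker inhibition), compound 1 (`CC(C)(C)c1ccc(OCCCON2C(N)=NC(N)=NC23CCSCC3)cc1`) gives 1 nM and compound 3 (`NC1=NC2(CCSCC2)N(OCCCOc2cccc(Cl)c2Cl)C(N)=N1`) gives 1 nM as well. Compound 2 (`NC1=NC2(CCOCC2)N(OCCCOc2cccc(Cl)c2Cl)C(N)=N1`) stands at 100 nM on the same read-out, the highest number of the three and the weakest result, well beyond the scatter from both others. Compound 4 (`NC1=NC2(CCOCC2)N(OCCCOc2cc(Cl)c(Cl)cc2Cl)C(N)=N1`) awaits testing. It carries 2,4,5-trichlorophenyl in place of 2,3-dichlorophenyl on an oxygen on a saturated carbon. Within the data shown here, no measured pair here shows what such a swap does. A small step towards a lower number is expected in this assay (a 2.5-fold lower number from compound 2 to compound 4 (0.40 log units; beyond the scatter)), with wide uncertainty. The estimated value for compound 4 is 40 nM within an expected range of 5 nM to 200 nM for this compound.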

Compound 4, half-maximal inhibitory concentration: 680 nM
Compound 4: the middle estimate sits 17-fold (1.23 log units) below what was measured; measured number outside the range, above it.
By their numbers in this assay, from the lowest: compounds 1 and 3 (each within the scatter of the next); then compound 2; then compound 4.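

Putting 2,4,5-trichlorophenyl in place of 2,3-dichlorophenyl on this oxygen gives a 6.8-fold higher number from compound 2 to compound 4 (0.83 log units; beyond the scatter) and so a weaker result, showing that this swap on the phenyl ring does not help. Among these compounds, the earlier compounds offered no single-place step, so this is the first sign that the result responds to the chlorine pattern at this position. Nothing available explains the change.

Open, as far as these compounds go, is whether a phenyl ring carrying a methoxy group or fluorine would do better here. Also open, from the compounds shown here alone, is whether the same swap acts alike on the core of compound 3.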